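Swapping the Sulfonyl Aryl Group in a Pancreatic Cancer Growth Assay

The source may report more compounds than this note shows. Statements on the series, on what has been measured and on what is new or still open speak of the compounds shown alone.

Of the compounds shown here, three have been tested in a functional assay on MIA PaCa-2 cells (Homo sapiens) for inhibition, read by MTT assay, with a stated time of 72 h; a higher number here means a weaker inhibitor of growth, a lower number a stronger inhibitor of growth. Compound 1 `O=S(=O)(NCCCCNCc1ccc(Br)cc1)c1cc(C(F)(F)F)cc(C(F)(F)F)c1` gives 2100 nM. Compound 2 `O=[N+]([O-])c1ccc(S(=O)(=O)NCCCCCCNCc2ccc(Br)cc2)cc1` gives 9800 nM. Compound 3 `O=S(=O)(NCCCNCc1ccc(Cl)c(C(F)(F)F)c1)c1cc(C(F)(F)F)cc(C(F)(F)F)c1` gives 7400 nM. Among these three, compound 2 has the highest number; against compound 3 the gap is within the scatter, while against compound 1 it lies beyond it.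

Compound 4 `O=S(=O)(NCCCCCCNCc1ccc(Br)cc1)c1cc(Cl)cc(Cl)c1` has not yet been measured in this assay. It differs from compound 2 in one place: 3,5-dichlorophenyl in place of 4-nitrophenyl on a sulfonyl sulfur. Among the measured compounds shown here, no pair of measured compounds shows this exact change, so its size cannot be read off directly. The two compounds that carry a 3,5-disubstituted phenyl on the sulfonyl sulfur, compound 1 and compound 3, both give lower numbers than compound 2, though they also differ elsewhere. A modest move toward a lower number is therefore expected, with a 2.2-fold lower number from compound 2 to compound 4 (0.34 log units; beyond the scatter) being the estimated step. Compound 4 is estimated at 4500 nM, with a likely range from 1500 nM to 13000 nM.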

Compound 4, concentration for 50% growth inhibition: 12000 nM
Beside the measured number, compound 4's estimate is 2.7-fold (0.43 log units) below it, within the range that was stated.
By their numbers in this assay, from the lowest: compound 1; then compounds 3, 2 and 4 (each within the scatter of the next).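

In this assay, the swap at the sulfonyl sulfur gives a 1.2-fold higher number from compound 2 to compound 4 (0.09 log units; within the scatter), so the two compounds cannot be told apart. Among the compounds shown here, this is the first direct reading of a change at this position with everything else held constant, and it shows that, with the hexyl-linked 4-bromobenzyl amine part of compound 2 in place, a 3,5-dichlorophenyl and a 4-nitrophenyl group serve equally well. No supporting measurement is available to explain this result.

On these data alone, it remains open whether a 3,5-bis(trifluoromethyl)phenyl group, as carried by compound 1 and compound 3, would do any better on this same hexyl chain. Also unresolved is how a phenyl ring bearing an amine or a carboxylic acid would behave at this position.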